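The source may report more compounds than this note shows. Statements on the series, on what has been measured and on what is new or still open speak of the compounds shown alone.

In a functional assay on U-87MG ATCC cells (Homo sapiens) for antiproliferative activity, read by MTT assay, with a stated time of 48 h (on this read-out higher numbers stand for weaker inhibition and lower numbers for stronger inhibition), compound 3 `O=C(/C=C\Nc1ccc(O)cc1)c1cn(-c2ccccc2)nc1-c1ccc(Cl)cc1` gives 1500 nM, the lowest of the two numbers shown. Compound 2 `O=C(/C=C\Nc1ccc(Cl)cc1)c1cn(-c2ccccc2)nc1-c1ccc(Cl)cc1` gives 13100 nM, and the step of an 8.7-fold lower number from compound 2 to compound 3 (0.94 log units; beyond the scatter) is hydroxy in place of chloro on an aromatic carbon. Compound 1 `COc1ccc(N/C=C\C(=O)c2cn(-c3ccccc3)nc2-c2ccccc2)cc1` reaches only the limit > 50000 nM, (the limit of > 50000 nM in this assay, at which 1 of the 3 values shown sits). Compound 4 `COc1ccc(N/C=C\C(=O)c2cn(-c3ccccc3)nc2-c2ccc(Cl)cc2)cc1` differs from compound 3 by methyl in place of hydrogen on an oxygen on an aromatic ring. Within the data shown here, no measured step matches this change directly. Of compound 1, which also carries a methoxy group, only a limit is known. Compound 4 is therefore expected to show a higher number, a step of a 5.3-fold higher number from compound 3 to compound 4 (0.73 log units; beyond the scatter). Compound 4 is estimated at 8000 nM, within a range from 2500 nM to 50000 nM.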

Compound 4, half-maximal inhibitory concentration: 6890 nM
Beside the measured number, compound 4's estimate is 1.2-fold (0.06 log units) above it; the range from low to high includes it.
By their numbers in this assay, from the lowest: compound 3; then compounds 4 and 2 (each within the scatter of the next). At a limit, above all of these: compound 1.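

On the oxygen on the aromatic ring, methyl in place of hydrogen gives a 4.6-fold higher number from compound 3 to compound 4 (0.66 log units; beyond the scatter) in this assay, so the methoxy of compound 4 does not match the hydroxy of compound 3. Methoxy in place of chloro gives a 1.9-fold lower number from compound 2 to compound 4 (0.28 log units; within the scatter) and so does not separate these two groups. With chloro in place of hydrogen on an aromatic carbon, an at least 7.2-fold lower number from compound 1 to compound 4 (0.86 log units; beyond the scatter) is read against a limit: the limit of > 50000 nM in this assay, at which 1 of the 4 values shown sits.

The compounds shown leave open whether an amine or a carboxylic acid in place of the hydroxy would keep the number of compound 3. They also leave open what a longer chain on the oxygen would give.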